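This account rests on a few compounds, and the source may have more. Where it says the series, first, only, none or still open, it means among the compounds named here.

Compound 1 `COc1cc(OC)c2cc(-c3ccccc3)c(O)nc2c1`: 10000 nM
Compound 2 `CCOC(=O)Cn1c(=O)c(-c2ccc(OC)cc2)cc2c(OC)cc(OC)cc21`: 10000 nM
Compound 3 `COc1cc(OC)c2cc(-c3ccc(O)cc3)c(=O)n(C)c2c1`: 10000 nM

All three values come from a functional assay on A 172 cells (Homo sapiens) for cytotoxicity, read by colorimetric assay and MTT assay; a higher number here means a weaker inhibitor, a lower number a stronger inhibitor. Compound 3 stands level with compounds 1 and 2 at the digits reported, so the numbers do not separate these three compounds.

Compound 4 `COc1cc(OC)c2cc(-c3ccc(OC(C)=O)cc3)c(=O)n(C)c2c1` differs from compound 3 in one place, with acetyl in place of hydrogen on an oxygen on an aromatic ring, or hydroxy to acetoxy: acetyl in place of hydrogen on an oxygen on an aromatic ring. Within the data shown here, no measured pair here shows this change or any other single change, so the data offer no direct guide to its size. Among the measured compounds shown here, the only footing is compound 3 at 10000 nM, which sits level with the other two compounds.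

In this assay, no step beyond the scatter is expected, in either direction. The estimated step, no change at the digits printed from compound 3 to compound 4 (within the scatter), therefore stays within the scatter. For compound 4 the expected value is 10000 nM, with an estimated range from 3000 nM to 15000 nM.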

Compound 4, half-maximal inhibitory concentration: 10000 nM
Compound 4: middle estimate and measured number agree at the digits printed, within the range that was stated.
By their numbers in this assay, from the lowest: compounds 1, 2, 3 and 4 (each within the scatter of the next).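

In this assay, among these compounds, acetyl in place of hydrogen on an oxygen on an aromatic ring gives no change at the digits printed from compound 3 to compound 4 (within the scatter), the first step in this set that can be read at a single place. At this oxygen, then, hydroxy and acetoxy cannot be told apart by this read-out, and the step points in neither direction, so compound 4 joins compounds 1, 2 and 3 at one shared level. Nothing available here offers an explanation for this result.

Going by these compounds, whether a longer chain on this oxygen, or an amine in place of it, would read any differently remains open. Also open, on these data alone, is whether any change to the shared core can separate a compound from this level at all.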